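From Thiophen-2-yl to 4-(Dimethylamino)phenyl on the Shared Core

The compounds below may be only part of what the source reports. "The series", "measured", "known", "first", "only" and "open" are said of these compounds alone.

Compound 1, `Cc1cc(O)c(C(C)C)cc1-c1cc(-c2ccccc2)c(C#N)c(=O)[nH]1`, gives 29% in a functional assay for inhibition, tested at 40 ug/mL; a lower number here means a weaker effect, a higher number a stronger effect of the compound at the concentration tested.
Compound 2, `Cc1cc(O)c(C(C)C)cc1-c1cc(-c2cccs2)c(C#N)c(=O)[nH]1`, gives 41% in this assay.
Compound 3, `COc1cc(-c2cc(-c3cc(C(C)C)c(O)cc3C)[nH]c(=O)c2C#N)ccc1O`, gives 32% in this assay.

Compound 2 holds the highest of the three numbers in this assay, with compound 3 nearest and only within the scatter of it, and compound 1 furthest, beyond the scatter. Compound 4, `Cc1cc(O)c(C(C)C)cc1-c1cc(-c2ccc(N(C)C)cc2)c(C#N)c(=O)[nH]1`, keeps the core of compound 2 and changes one group: 4-(dimethylamino)phenyl in place of thiophen-2-yl on an aromatic carbon.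

For the measured compounds named here, two measured steps bear on this change. The step of a number 12 percentage points higher from compound 1 to compound 2 (beyond the scatter) shows that a five-membered ring on this carbon gave a modest rise over phenyl. The step of a number 3 percentage points higher from compound 1 to compound 3 (within the scatter) shows that a substituted six-membered carbon ring gave no change beyond the scatter against phenyl, and the step of a number 9 percentage points lower from compound 2 to compound 3 (within the scatter) likewise stayed within the scatter. Compound 4 returns to a six-membered carbon ring, so a number somewhat below compound 2 is expected in this assay, though the step of a number 8 percentage points lower from compound 2 to compound 4 (within the scatter) is expected to stay within the scatter. Compound 4 is therefore estimated at 33%, in the range 18% to 48%.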

Compound 4, a percentage reported as inhibition, at one concentration (the size of the read-out at that concentration, not a potency): 43%
The estimate for compound 4 lay 10 percentage points below the measured number, and the stated range covers the measured number.
By their numbers in this assay, from the lowest: compounds 1, 3, 2 and 4 (each within the scatter of the next, the first and the last beyond it).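

In this assay, the step of a number 2 percentage points higher from compound 2 to compound 4 (within the scatter) shows that a six-membered carbon ring opposite the ring nitrogen can stand level with thiophen-2-yl, so a five-membered ring is not required at this position for a number of this size. Substitution on the six-membered ring is also not interchangeable: the step of a number 14 percentage points higher from compound 1 to compound 4 (beyond the scatter), with dimethylamino in place of hydrogen, lies beyond the scatter, as does the step of a number 11 percentage points higher from compound 3 to compound 4 (beyond the scatter), whereas the 4-hydroxy-3-methoxyphenyl group of compound 3 stayed within the scatter of phenyl. No measurement shown here accounts for these differences.

The compounds leave open whether dimethylamino is the particular group that matters on this ring, or whether a primary amine, a morpholine or a carboxylic acid in its place would give a similar number. They also leave open how other five-membered rings, such as furan-2-yl or a thiazole, would compare with thiophen-2-yl on the shared core.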